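This account rests on a few compounds, and the source may have more. Where it says the series, first, only, none or still open, it means among the compounds named here.

Compound 2 `CC(=O)Oc1ccccc1C(=O)O[C@H]1CO[C@H]2[C@@H]1OC[C@H]2O` sits in the middle of the three measured compounds in an ADME assay on a cell-free system (plasma, Homo sapiens) for metabolic stability, with Plasma (Rattus norvegicus) as the target, read by HPLC, at pH 7.4 (on this read-out lower numbers stand for a shorter-lived compound and higher numbers for a longer-lived compound), giving 0.0183 h; compound 1 `CC(=O)Oc1ccccc1C(=O)O[C@H]1CO[C@H]2[C@@H]1OC[C@H]2OC(=O)c1ccccc1O` gives 0.019 h and compound 3 `CC(=O)Oc1ccccc1C(=O)O[C@H]1CO[C@H]2[C@@H]1OC[C@H]2OC(=O)c1ccccc1` gives 0.0107 h. Compound 4 `COc1ccccc1C(=O)O[C@@H]1CO[C@H]2[C@@H]1OC[C@@H]2OC(=O)c1ccccc1OC(C)=O` differs from compound 2 by one change: (2-methoxyphenyl)carbonyl in place of hydrogen on an oxygen on a saturated carbon. Among the measured compounds shown here, two measured steps bear on it. The step of a 1.7-fold lower number from compound 2 to compound 3 (0.23 log units; within the scatter) adds a related group at the same oxygen, and the step of a 1.0-fold lower number from compound 1 to compound 2 (0.02 log units; within the scatter) removes another such group from it; neither moved the half-life beyond the scatter. Compound 4 is therefore expected to show no step beyond the scatter, with a 1.2-fold lower number from compound 2 to compound 4 (0.09 log units; within the scatter). The estimated half-life of compound 4 in this assay is 0.015 h, within a range from 0.007 h to 0.032 h.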

Compound 4, half-life: 0.0165 h
Compound 4: the middle estimate sits 1.1-fold (0.04 log units) below what was measured; the measured number falls inside the stated range.
By their numbers in this assay, from the lowest: compounds 3, 4, 2 and 1 (each within the scatter of the next).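

In this assay, (2-methoxyphenyl)carbonyl is a third aromatic carbonyl group on the oxygen on a saturated carbon, and the half-life stays within the scatter, with a 1.1-fold lower number from compound 2 to compound 4 (0.04 log units; within the scatter). Swapping the substituent on that aromatic group also stays within the scatter: methoxy in place of hydrogen gives a 1.5-fold higher number from compound 3 to compound 4 (0.19 log units; within the scatter), and methyl in place of hydrogen on the oxygen gives a 1.2-fold lower number from compound 1 to compound 4 (0.06 log units; within the scatter). No supporting data offer an explanation for these results. The compounds shown leave open whether a group without an aromatic ring, such as an amine or a longer alkyl chain, would change the half-life at this oxygen.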